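The compounds below may be only part of what the source reports. "The series", "measured", "known", "first", "only" and "open" are said of these compounds alone.

Measured so far:
- compound 1 `CCN(Cc1ccncc1)C(=O)Cn1c(=O)n(C)c2cnc(-c3ccccc3)nc21` — in an assay on brain (strain Sprague-Dawley) for displacement of a labelled ligand from Translocator protein (Rattus norvegicus), with a stated time of 30 min (on this read-out higher numbers stand for weaker inhibition and lower numbers for stronger inhibition), compound 1 gives 5.1 nM
- compound 2 `CN(Cc1cccnc1)C(=O)Cn1c(=O)n(C)c2cnc(-c3ccccc3)nc21` — in this assay compound 2 gives 40 nM

Within the data shown here, compound 2 holds the higher of the two numbers; the only step in hand runs a 7.8-fold higher number from compound 1 to compound 2 (0.89 log units; beyond the scatter). Compound 3 `CCN(Cc1ccccc1)C(=O)Cn1c(=O)n(C)c2cnc(-c3ccccc3)nc21` is not yet measured. The change is benzyl(ethyl)amino in place of methyl((pyridin-3-yl)methyl)amino on a carbonyl carbon. Among the measured compounds shown here, compound 3 keeps the ethyl seen in compound 1 while carrying a ring of carbon only, so the one measured step bears on it only in part. The step for compound 3 is expected to run a 5.0-fold lower number from compound 2 to compound 3 (0.70 log units; beyond the scatter), undoing much of the rise. Compound 3 is expected to give 8 nM, in the range 2.5 nM to 25 nM.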

Compound 3, inhibition constant in the Translocator protein assay: 0.6 nM
The estimate for compound 3 lay 13-fold (1.12 log units) above the measured number; the whole stated range lies above it.
By their numbers in the Translocator protein assay, from the lowest: compound 3; then compound 1; then compound 2.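

In the Translocator protein assay, phenyl in place of pyridin-4-yl, with the ethyl held, gives an 8.5-fold lower number from compound 1 to compound 3 (0.93 log units; beyond the scatter), so the ring nitrogen alone matters at this position. The wider change, with both chain and ring differing, gives a 67-fold lower number from compound 2 to compound 3 (1.82 log units; beyond the scatter). In a physicochemical assay for lipophilicity, using the shake flask method, in phosphate buffer, measured as octanol-water partition, at pH 7.4 (on this read-out higher numbers stand for higher lipophilicity and lower numbers for lower lipophilicity), compound 2 gives 1.81 and compound 3 gives 3.48. That wider change also raises lipophilicity as measured: the measured distribution coefficient of compound 2, 1.81, and of compound 3, 3.48, a number 1.67 log units higher (beyond the scatter)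

The compounds shown do not separate the effect of ethyl from that of the ring in the wider change, nor lipophilicity from the loss of the ring nitrogen. On these data alone, whether a propyl chain in place of ethyl, or a methoxy group on the phenyl ring, would hold this level stays open.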